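Replacing 3-chlorophenyl on the amide of compound 1

A few compounds are considered here, and "the series" means these few. Any claim that something is new, unique, unknown or untested is made for them only; others in the source may bear on it.

In a functional assay on T47D cells (Homo sapiens) for inhibition, read by CCK-8 assay, with a stated time of 72 h, tested at 1 uM (a higher number here means more inhibition of growth at the concentration tested, a lower number less inhibition of growth), compound 1 (`CN(C)C(=O)c1cc2cnc(Nc3ccc(NC(=O)C4(C(=O)Nc5cccc(Cl)c5)CC4)cc3)nc2n1C1CCCC1`) gives 39.3%, the highest of the three measured values and beyond the scatter from both of the others. Compound 2 (`Nc1ccc(NC(=O)C2(C(=O)Nc3ccc(F)cc3)CC2)cc1F`) gives 5.6%. Compound 3 (`CN(C)C(=O)c1cc2cnc(Nc3ccc(NC(=O)C4(C(=O)Nc5ccc(F)cc5)CC4)cc3F)nc2n1C1CCCC1`) gives 6.3%.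

Compound 4 (`CN(C)C(=O)c1cc2cnc(Nc3ccc(NC(=O)C4(C(=O)Nc5ccc(O)cc5)CC4)cc3)nc2n1C1CCCC1`) carries 4-hydroxyphenyl in place of 3-chlorophenyl on an amide-type nitrogen. Going by the values given here, no measured pair isolates this change. A loss beyond the scatter is expected in this assay, an expectation resting on compound 3 at 6.3%, which also lacks 3-chlorophenyl. The estimated change is a number 17.3 percentage points lower from compound 1 to compound 4 (beyond the scatter). The data leave this uncertain, so a wide range is expected. For compound 4 the estimate is 22%, within 4% to 48%.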

Compound 4, percent growth inhibition at one concentration: 91.5%
Beside the measured number, compound 4's estimate is 69.5 percentage points below it, outside the stated range (above it).
By their numbers in this assay, from the lowest: compounds 2 and 3 (each within the scatter of the next); then compound 1; then compound 4.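

In this assay the aryl group on the amide-type nitrogen proves to be a strong lever on the core of compound 1: the step is a number 52.2 percentage points higher from compound 1 to compound 4 (beyond the scatter), a large gain from this single change. Going by these compounds alone, this is the first pair to isolate the position, and it shows that 3-chlorophenyl is not required there and that 4-hydroxyphenyl is far better tolerated. No available evidence bears on the reason for this step.

The change swaps the substituent and its ring position together, so the two remain unseparated. Plain phenyl, 3-hydroxyphenyl, 4-methoxyphenyl and 4-aminophenyl on the same nitrogen remain open.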